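Swapping a Sulfonamide for an Amide: Solubility Outlook

The source may report more compounds than this note shows. Statements on the series, on what has been measured and on what is new or still open speak of the compounds shown alone.

Compound 1 `COc1ccc(-c2cc(-c3ccc(S(=O)(=O)N(C)C)cc3)cnc2N)cn1` is the starting point. In a physicochemical assay for solubility, read by nephelometry, measured as kinetic solubility, at pH 2 (on this read-out higher numbers stand for higher solubility and lower numbers for lower solubility), compound 1 gives > 100 ug/mL, which is a limit of the assay. Two close relatives end in the same place. Compound 2 `COc1ccc(-c2cc(-c3ccc(NS(C)(=O)=O)cc3)cnc2N)cn1` gives > 100 ug/mL in this assay, again a limit. Compound 3 `COc1ccc(-c2cc(-c3ccc4cnn(C)c4c3)cnc2N)cn1` gives > 100 ug/mL in this assay, also a limit. The step from compound 1 to compound 2, in which methanesulfonamido replaces dimethylsulfamoyl, is a step that the two limits leave unreadable from compound 1 to compound 2 because of the limit of > 100 ug/mL in this assay, at which 3 of the 3 values shown sit.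

Compound 4 `COc1ccc(-c2cc(-c3ccc(C(=O)N(C)C)cc3)cnc2N)cn1` has not yet been measured. It differs from compound 1 by dimethylcarbamoyl in place of dimethylsulfamoyl on an aromatic carbon. Among the measured compounds shown here, no measured step covers this exact exchange, and the one measured step at the same position cannot be sized. Because (the limit of > 100 ug/mL in this assay, at which 3 of the 3 values shown sit), the only reasonable expectation is that compound 4 also reaches the limit in this assay. Compound 4 is therefore estimated at 130 ug/mL, with a range from 60 ug/mL to 280 ug/mL. The expected step, a step that the limit leaves unreadable from compound 1 to compound 4, is expected to stay within the usual scatter.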

Compound 4, solubility: > 100 ug/mL
Compound 4 ended at the assay's limit (the forecaster's own chance of this, stated with the estimate: 80%); the middle value lies beyond the limit too.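

No size can be read for the step from compound 1 or from compound 2 to compound 4, because all these values are limits: the limit of > 100 ug/mL in this assay, at which 4 of the 4 values shown sit.

The compounds shown leave open whether compound 1, compound 2, compound 3 and compound 4 truly differ at all in this assay.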